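Urea aryl swap on the pyrazole series: compound 3

The compounds below may be only part of what the source reports. "The series", "measured", "known", "first", "only" and "open" are said of these compounds alone.

Measured in a functional assay on OVCAR-3 cells (Homo sapiens) for inhibition, read by sulforhodamine B assay, with a stated time of 48 h; on this read-out higher numbers stand for weaker inhibition of growth and lower numbers for stronger inhibition of growth:
compound 1, `O=C(Nc1cccc(-n2cc(-c3ccncc3)c(-c3ccc(Cl)c(O)c3)n2)c1)Nc1cccc(C(F)(F)F)c1`: 6130 nM
compound 2, `COc1cc(-c2nn(-c3cccc(NC(=O)Nc4ccc(Cl)c(Cl)c4)c3)cc2-c2ccncc2)ccc1Cl`: 2270 nM

Compound 2 gives the lowest of the two numbers; compound 1 sits higher by a margin beyond the scatter. Compound 3, `COc1cc(-c2nn(-c3cccc(NC(=O)Nc4cccc(C(F)(F)F)c4)c3)cc2-c2ccncc2)ccc1Cl`, differs from compound 2 in one place: 3-(trifluoromethyl)phenyl in place of 3,4-dichlorophenyl on an amide-type nitrogen. Within the data shown here, no measured pair shows this change on this core, so its size is uncertain. Since compound 1 carries the same aryl urea and gives 6130 nM, a rise of about a 2.0-fold higher number from compound 2 to compound 3 (0.30 log units; within the scatter) is expected, near the edge of the scatter. Compound 3 is estimated at 4500 nM, range 1800 nM to 11000 nM.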

Compound 3, concentration for total growth inhibition: 1870 nM
Beside the measured number, compound 3's estimate is 2.4-fold (0.38 log units) above it, and the stated range covers the measured number.
By their numbers in this assay, from the lowest: compounds 3 and 2 (each within the scatter of the next); then compound 1.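

In this assay, 3-(trifluoromethyl)phenyl in place of 3,4-dichlorophenyl on an amide-type nitrogen gives a 1.2-fold lower number from compound 2 to compound 3 (0.08 log units; within the scatter), so this urea aryl change leaves the read-out within the scatter on this core. With the aryl urea held fixed, methyl in place of hydrogen on an oxygen on an aromatic ring gives a 3.3-fold lower number from compound 1 to compound 3 (0.52 log units; beyond the scatter), a modest step beyond the scatter. Nothing available explains either step. Still open, as far as these compounds go, is how a urea aryl carrying an amine or a carboxylic acid would read. From the compounds shown here alone, an ethyl group or a longer chain on that oxygen also remains open.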